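Adding a methoxy group to compound 3

This account rests on a few compounds, and the source may have more. Where it says the series, first, only, none or still open, it means among the compounds named here.

Compound 1 `COc1cccc(C[C@H]2COC[C@@H]2Cc2ccc(Cl)c(Cl)c2)c1`: 73000 nM
Compound 2 `Fc1cccc(C[C@H]2COC[C@@H]2Cc2ccc(Cl)c(Cl)c2)c1`: 20000 nM
Compound 3 `Oc1ccc(C[C@H]2COC[C@@H]2Cc2ccc(Cl)c(Cl)c2)cc1`: 31000 nM

These values come from a functional assay on HL-60 cells (Homo sapiens) for cytotoxicity, read by WST assay, with a stated time of 48 h; a higher number here means that more compound is needed for the effect, a lower number that less compound is needed. The data show a 1.6-fold higher number from compound 2 to compound 3 (0.19 log units; within the scatter), so compound 3 cannot be separated from compound 2. Compound 1, at 73000 nM, stands clearly apart from compound 3 on the higher side.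

Compound 4 `COc1cc(C[C@H]2COC[C@@H]2Cc2ccc(Cl)c(Cl)c2)ccc1O` differs from compound 3 by methoxy in place of hydrogen on an aromatic carbon, ortho to a hydroxy group and meta to a large group. Going by the values given here, no measured pair shows this exact change. The closest evidence is the modest 3.7-fold lower number from compound 1 to compound 2 (0.56 log units; beyond the scatter), where fluoro takes the place of methoxy and the number falls. That step is only indirect, but it suggests that methoxy may bring a slightly higher number in this assay. The expected result is a 1.3-fold higher number from compound 3 to compound 4 (0.11 log units; within the scatter), a small upward step probably within the scatter. For compound 4 the estimated value is 40000 nM, with an expected range from 16000 nM to 100000 nM.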

Compound 4, half-maximal effective concentration: 21000 nM
Compound 4: middle estimate off by 1.9-fold (0.28 log units), on the high side; the range from low to high includes it.
By their numbers in this assay, from the lowest: compounds 2, 4 and 3 (each within the scatter of the next); then compound 1.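

In this assay, adding a methoxy group, ortho to a hydroxy group and meta to a large group, gives a 1.5-fold lower number from compound 3 to compound 4 (0.17 log units; within the scatter), so the two compounds cannot be told apart. The other step reads the hydroxy group with methoxy already present: hydroxy in place of hydrogen gives a 3.5-fold lower number from compound 1 to compound 4 (0.54 log units; beyond the scatter), so the methoxy group alone does not set the high value of compound 1, since compound 4 carries it as well. Nothing available accounts for either step.

On these data alone, it remains open whether an amine or a carboxylic acid at this aromatic carbon would give a number clearly apart from that of compound 3. Whether ethoxy, with its longer chain, would behave as methoxy does here is also unsettled.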